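Aryl piperazine variation on the shared core: compound 4

The source may hold more compounds than are shown below. What is called first, only, known or untested is meant among the compounds shown, and "the series" means these compounds.

Measured so far: compound 1 `CCCc1nc(-c2ccccc2)c(CNCCCN2CCN(c3cccc(OC)c3)CC2)o1` 36.4%; compound 2 `CCCc1nc(-c2ccccc2)c(CNCCCN2CCN(c3ccccc3F)CC2)o1` 54.4%; compound 3 `CCCc1nc(-c2ccccc2)c(CNCCCN2CCN(c3cccc(C(F)(F)F)c3)CC2)o1` 51.6%, all in an assay on HEK293 cells for inhibition of Voltage-dependent T-type calcium channel subunit alpha-1G (Homo sapiens), read by fluorescence, tested at 10 uM; on this read-out lower numbers stand for less inhibition and higher numbers for more inhibition at the one concentration tested (going by the name of the read-out).

Compound 3 stands second highest of the three numbers; its nearest neighbour is compound 2, where a number 2.8 percentage points lower from compound 2 to compound 3 (within the scatter), while the gap to the furthest number is shown by the step of a number 15.2 percentage points higher from compound 1 to compound 3 (beyond the scatter). The step that mattered was leaving compound 1: a number 18 percentage points higher from compound 1 to compound 2 (beyond the scatter).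

Compound 4 `CCCc1nc(-c2ccccc2)c(CNCCCN2CCN(c3ccccc3Cl)CC2)o1` is not yet measured. It differs from compound 3 in one place: 2-chlorophenyl in place of 3-(trifluoromethyl)phenyl on an amine nitrogen in a ring. Among the measured compounds shown here, the most relevant measured step is the one between compound 2 and compound 3, which was within the scatter, since compound 4 carries a halogen on the phenyl at the same place as compound 2 does. Both aryl replacements of compound 1 gave similar numbers, so for compound 4 no step beyond the scatter is expected in this assay: the expected step is a number 0.4 percentage points higher from compound 3 to compound 4 (within the scatter). Compound 4 is therefore estimated at 52%, with a range from 38% to 66%.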

Compound 4, a percentage reported as inhibition, at one concentration (the size of the read-out at that concentration, not a potency): 64.7%
Beside the measured number, compound 4's estimate is 12.7 percentage points below it; the range from low to high includes it.
By their numbers in this assay, from the lowest: compound 1; then compounds 3 and 2 (each within the scatter of the next); then compound 4.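

In this assay, the 2-chlorophenyl group on the amine nitrogen in a ring stands clear of all the earlier aryl groups, with a number 13.1 percentage points higher from compound 3 to compound 4 (beyond the scatter) and a number 10.3 percentage points higher from compound 2 to compound 4 (beyond the scatter), so compound 4 has the highest number of the series. The second step is a change of halogen alone, chloro in place of fluoro on an aromatic carbon, and it shows that this aryl group can still move the number beyond the scatter, although compounds 2 and 3 could not be told apart. The span of the series widens to a number 28.3 percentage points higher from compound 1 to compound 4 (beyond the scatter), and nothing measured here bears on why.

Open, on these data alone, is whether a bromo or methyl group in place of the chloro would hold this number. The single tested concentration also leaves the potency of compound 4 unknown.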